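This account rests on a few compounds, and the source may have more. Where it says the series, first, only, none or still open, it means among the compounds named here.

Compound 2, `CCOC(=O)c1ccc(NC(=O)N[C@H](C)c2ccccc2)cc1`, is one of two compounds sharing a core that have been measured in an ADME assay on the whole organism with Oryza sativa as the target, tested at 0.1 uM; on this read-out lower numbers stand for a stronger effect and higher numbers for a weaker effect at the one concentration tested. In this assay compound 2 gives 101%, and compound 1, `CCCCCCCc1ccc(NC(=O)N[C@H](C)c2ccccc2)cc1`, gives 100%. The step of a number 1 percentage points higher from compound 1 to compound 2 (within the scatter) shows that exchanging the group on the aromatic ring left the read-out at the same level, so compound 2 stands alongside compound 1 with a gap that lies within the scatter. Compound 3, `C[C@@H](NC(=O)Nc1ccc(I)cc1)c1ccccc1`, differs from compound 2 in one place: iodo in place of ethoxycarbonyl on an aromatic carbon. Among the measured compounds shown here, the only measured step that bears on this change is a number 1 percentage points higher from compound 1 to compound 2 (within the scatter), which was within the scatter, so another exchange in the same place is expected to give a step of a number 1 percentage points lower from compound 2 to compound 3 (within the scatter), that is, none beyond the scatter. Compound 3 is therefore estimated to give 100%, with a range from 88% to 110%.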

Compound 3, a percentage reported as activity, at one concentration (the size of the read-out at that concentration, not a potency): 100%
The estimate for compound 3 equals the measured number at the digits printed; the range from low to high includes it.
By their numbers in this assay, from the lowest: compounds 1, 3 and 2 (each within the scatter of the next).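

Iodo in place of ethoxycarbonyl gives a number 1 percentage points lower from compound 2 to compound 3 (within the scatter) and iodo in place of heptyl gives no change at the digits printed from compound 1 to compound 3 (within the scatter) on this aromatic carbon, para to a large group. Iodo has 1 heavy atom and 0 hydrogen-bond acceptors, while ethoxycarbonyl has 5 heavy atoms and 2 hydrogen-bond acceptors, yet this assay does not separate them, so three different groups at this place now give readings within the scatter of one another. No measurement at hand explains this sameness.

On these data alone, whether a group such as an amine or a carboxylic acid at this place would give a reading beyond the scatter of these three remains open. So does whether the three compounds would still read alike at another concentration.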